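Methoxycarbonyl to carboxy on the shared core

The compounds below may be only part of what the source reports. "The series", "measured", "known", "first", "only" and "open" are said of these compounds alone.

Compound 2 (`CCOC(=O)/C=C(/C(=O)OCC)[C@H]1c2c(cc(O)c(O)c2O)C(=O)O[C@@H]1C(=O)OC`) stands at 4400 nM and compound 1 (`CCOC(=O)/C=C(/C(=O)OC)[C@H]1c2c(cc(O)c(O)c2O)C(=O)O[C@@H]1C(=O)OCC`) at 6000 nM in a functional assay, with a stated time of 30 min (a lower number here means that less compound is needed, a higher number that more compound is needed for the effect), and these two values lie within the scatter of each other. Compound 3 (`CCOC(=O)/C=C(/C(=O)OCC)[C@H]1c2c(cc(O)c(O)c2O)C(=O)O[C@@H]1C(=O)O`) follows from compound 2 through the change hydrogen in place of methyl on an oxygen next to a carbonyl group with hydrogen in place of methyl on an oxygen next to a carbonyl group, which reads methoxycarbonyl to carboxy. Among the compounds with values here, no measured pair carries this change, so only a modest move towards a higher number is expected in this assay with more compound needed. The expected step runs a 1.8-fold higher number from compound 2 to compound 3 (0.26 log units; within the scatter) and may stay close to the scatter. For compound 3 the estimate is 8000 nM with an expected range from 2500 nM to 25000 nM in this measurement.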

Compound 3, half-maximal effective concentration: 5400 nM
Beside the measured number, compound 3's estimate is 1.5-fold (0.17 log units) above it; low and high end bracket the measured number.
By their numbers in this assay, from the lowest: compounds 2, 3 and 1 (each within the scatter of the next).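

In this assay, hydrogen in place of methyl on an oxygen next to a carbonyl group gives a 1.2-fold higher number from compound 2 to compound 3 (0.09 log units; within the scatter). Compound 3 is the first of these compounds with a carboxy group at this place, and methoxycarbonyl to carboxy does not carry the number beyond the scatter. The shared core therefore keeps its read-out in this assay with either group present.

As far as these compounds go, whether an amide or a longer ester chain at this place would also stay within the scatter remains open. Nothing available explains this result.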